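Ester variation in a vinylsulfonamide series

The compounds below may be only part of what the source reports. "The series", "measured", "known", "first", "only" and "open" are said of these compounds alone.

Measured compounds:
compound 1 `COc1cc(O)c(C(=O)OCC2CCCCC2)c(/C=C/CN2C(=O)C=CC2=O)c1` — 71%
compound 2 `C=CS(=O)(=O)NC/C=C/c1cc(OC)cc(O)c1C(=O)OCC1CCCCC1` — 7.5%
compound 3 `C=CS(=O)(=O)NC/C=C/c1cc(OC)cc(O)c1C(=O)OCc1ccc(F)cc1` — 10.9%

In a functional assay on HL-60 cells (Homo sapiens) for inhibition, read by luminescence, with a stated time of 72 h, tested at 5 uM (on this read-out higher numbers stand for more inhibition of growth at the one concentration tested and lower numbers for less inhibition of growth), compound 1 gives 71%. Compound 2 gives 7.5%, and compound 3 gives 10.9%. The first step, a number 63.5 percentage points lower from compound 1 to compound 2 (beyond the scatter), is the only large movement in the set. The second, a number 3.4 percentage points higher from compound 2 to compound 3 (within the scatter), changes the ester side on a saturated chain carbon bound to an oxygen next to a carbonyl group and stays within the scatter. Among the measured compounds shown here, on the numbers so far compound 3 is the second highest of three; its nearest neighbour is compound 2, within the scatter, and its furthest is compound 1, beyond the scatter.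

Compound 4 `C=CS(=O)(=O)NC/C=C/c1cc(OC)cc(O)c1C(=O)OCC(C)c1ccccc1` is not yet measured. It differs from compound 3 as follows: 1-phenylethyl in place of 4-fluorophenyl on a saturated chain carbon bound to an oxygen next to a carbonyl group. The step that bears on this is a number 3.4 percentage points higher from compound 2 to compound 3 (within the scatter), a replacement on the same saturated chain carbon bound to an oxygen next to a carbonyl group that gave no movement beyond the scatter. The vinylsulfonamide side that governed the large step from compound 1 to compound 2 is unchanged between compound 3 and compound 4. For compound 4 the expected step is therefore a number 0.1 percentage points higher from compound 3 to compound 4 (within the scatter), none beyond the scatter. Compound 4 is estimated at 11%, with a range from 0% to 25%.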

Compound 4, percent growth inhibition at one concentration: 9.5%
Compound 4: the middle estimate sits 1.5 percentage points above what was measured; low and high end bracket the measured number.
By their numbers in this assay, from the lowest: compounds 2, 4 and 3 (each within the scatter of the next); then compound 1.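

Notes on the ester side: in this assay, 1-phenylethyl on a saturated chain carbon bound to an oxygen next to a carbonyl group gives a number 1.4 percentage points lower from compound 3 to compound 4 (within the scatter) against 4-fluorophenyl and a number 2 percentage points higher from compound 2 to compound 4 (within the scatter) against cyclohexyl at the same place. The earlier compounds shown here offered a single replacement here; with a third group, all three pairs among compound 2, compound 3 and compound 4 lie within the scatter, so this read-out at the one concentration tested does not separate the cyclohexyl, 4-fluorophenyl and 1-phenylethyl esters, even with an aromatic ring on two of them and a fluorine on only one. No measurement at hand speaks to why these three esters read alike.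

The compounds shown pair the group on the other side of the core in compound 1 with the cyclohexyl ester only, so whether the ester side matters with that group in place remains open. Also open, going by these compounds, is whether an ester side carrying an amine, a carboxylic acid or a longer chain would move the vinylsulfonamide compounds beyond the scatter at this position.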